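The source may hold more compounds than are shown below. What is called first, only, known or untested is meant among the compounds shown, and "the series" means these compounds.

Measured so far:
compound 1 `Nc1ccc2c(Br)n[nH]c2c1` — > 770000 nM in an assay on isolated protein for inhibition of tyrosine-protein kinase receptor UFO (Homo sapiens), with a stated time of 1.5 h; on this read-out lower numbers stand for stronger inhibition and higher numbers for weaker inhibition
compound 2 `CN1CCC(CNc2ccc3[nH]nc(-c4cnn(C)c4)c3c2)CC1` — 1850000 nM
compound 3 `N#Cc1ccc(-n2cc(-c3n[nH]c4cc(Cl)c(N[C@@H]5CCNC5)cc34)cn2)cc1` — 700 nM

Of the two plain numbers in this assay, compound 2 gives the highest; compound 3 gives a markedly lower number, beyond the scatter. For compound 1 the value is a limit of this assay, not a number (the limit of > 770000 nM in this assay, at which 1 of the 3 values shown sits).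

Compound 4 `Cn1cc(-c2n[nH]c3ccc(N[C@@H]4CCNC4)cc23)cn1` is compound 2 with one change: pyrrolidin-3-yl in place of (1-methylpiperidin-4-yl)methyl on a nitrogen on an aromatic ring. Pyrrolidin-3-yl enters where (1-methylpiperidin-4-yl)methyl leaves, on a nitrogen on an aromatic ring whose other neighbour is aromatic carbon. Among the measured compounds shown here, no measured step of this kind exists in the set. Compound 3 carries the same pyrrolidin-3-yl group on the corresponding nitrogen and gives the lower number, so a step downward in this assay, beyond the scatter, is expected: a 37-fold lower number from compound 2 to compound 4 (1.57 log units; beyond the scatter). Compound 4 is estimated at 50000 nM, within 5000 nM to 500000 nM.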

Compound 4, half-maximal inhibitory concentration: 37000 nM
Beside the measured number, compound 4's estimate is 1.4-fold (0.13 log units) above it; the range from low to high includes it.
By their numbers in this assay, from the lowest: compound 3; then compound 4; then compound 2.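

Among the compounds shown here, this nitrogen gives the first single-change comparison: in this assay, replacing (1-methylpiperidin-4-yl)methyl with pyrrolidin-3-yl gives a 50-fold lower number from compound 2 to compound 4 (1.70 log units; beyond the scatter). The group on this nitrogen therefore moves the read-out with the rest of the structure unchanged, although ring size and hydrogen-bond donor count change together. No measured property here accounts for the step.

The compounds shown leave open which of those two differences carries the step. They also leave open whether an open-chain 2-aminoethyl group on this nitrogen would give a similar number.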